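This account rests on a few compounds, and the source may have more. Where it says the series, first, only, none or still open, it means among the compounds named here.

Measured in a functional assay for inhibition, with Rattus norvegicus as the target; a lower number here means a stronger inhibitor, a higher number a weaker inhibitor:
compound 1 `CC(C)C(C)/N=c1\c(O)c(O)\c1=N/c1ccc(C#N)cc1`: 1900 nM
compound 2 `CC(C)(C)C/N=c1\c(O)c(O)\c1=N/c1ccc(C#N)cc1`: > 30000 nM

Compound 2 gives only a limit of the assay, > 30000 nM, and not a number. Its position in the series is therefore known on one side only.

Next in line is compound 3 `CCC(C)/N=c1\c(O)c(O)\c1=N/c1ccc(C#N)cc1`, with sec-butyl in place of neopentyl on a double-bonded nitrogen. Going by the values given here, the one measured step that bears on this change is an at least 15-fold higher number from compound 1 to compound 2 (1.19 log units; beyond the scatter). That step is large and beyond the scatter, and it too replaces a chain on the same nitrogen, putting neopentyl in place of 1,2-dimethylpropyl. Sec-butyl is closer in shape to the 1,2-dimethylpropyl of compound 1, which gives 1900 nM, than to neopentyl. A large step towards a lower number in this assay is therefore expected, roughly undoing the measured one, although a single pair is thin support. The expected change is an at least 10-fold lower number from compound 2 to compound 3 (1.00 log units; beyond the scatter). For compound 3 the estimated value is 3000 nM, with an expected range from 800 nM to 12000 nM.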

Compound 3, half-maximal inhibitory concentration: 2100 nM
Compound 3: the middle estimate sits 1.4-fold (0.15 log units) above what was measured; the measured number falls inside the stated range.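

In this assay, the change from neopentyl to sec-butyl on the double-bonded nitrogen gives an at least 14-fold lower number from compound 2 to compound 3 (1.15 log units; beyond the scatter), so the loss seen with neopentyl is not shared by every small branched chain at this place. Hydrogen in place of methyl on a saturated chain carbon bound to two saturated chain carbons gives a 1.1-fold higher number from compound 1 to compound 3 (0.04 log units; within the scatter), so sec-butyl and 1,2-dimethylpropyl cannot be told apart here, and neopentyl is the one chain of the three that goes against them. Compound 2 is a limit of the assay and not a number, so the size of any step involving it remains a bound only: the limit of > 30000 nM in this assay, at which 1 of the 3 values shown sits.

The compounds shown leave open how an unbranched chain such as n-pentyl, or a chain carrying an amine or a carboxylic acid, would read on this nitrogen. From the compounds shown here alone, the other side of the shared core is the same in all three compounds, so whether the ranking of these chains holds with a group other than the nitrile there also remains open.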